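Fluorine-Bearing Groups on the Aromatic Ring in Seizure Protection

A few compounds are considered here, and "the series" means these few. Any claim that something is new, unique, unknown or untested is made for them only; others in the source may bear on it.

Compound 1 `CC(C(=O)N1CCN(c2ccccc2)CC1)N1C(=O)CCC1=O` stands lowest of the two measured compounds in a functional assay on the whole organism (strain Swiss) with Mus musculus as the target, in the maximal electroshock model, with a stated time of 0.25 h, at a dose of 100 mg/kg by the intraperitoneal route (a lower number here means a weaker effect, a higher number a stronger effect of the compound at the dose given), where compound 1 gives 50%. Among the compounds with values here, its only measured neighbour is compound 2 `CC(C(=O)N1CCN(c2ccc(F)cc2)CC1)N1C(=O)CCC1=O`, and in this assay compound 2 gives 75%. Within the data shown here, the single measured step between them is a number 25 percentage points higher from compound 1 to compound 2 (beyond the scatter), brought about by fluoro in place of hydrogen on an aromatic carbon.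

Compound 3 `CC(C(=O)N1CCN(c2ccccc2C(F)(F)F)CC1)N1C(=O)CCC1=O` has not yet been measured in this assay. It differs from compound 1 by trifluoromethyl in place of hydrogen on an aromatic carbon, the new group sitting on an aromatic carbon of a six-membered aromatic ring of carbon only, ortho to a large group.

Among the measured compounds shown here, only the step from compound 1 to compound 2 bears on this change, and it was modest, though beyond the scatter. For the measured compounds named here, the present change also puts fluorine onto the ring, but as a larger group and at another place, so the one comparison is an uncertain guide. An upward step of similar or somewhat smaller size is expected, a number 12 percentage points higher from compound 1 to compound 3 (beyond the scatter). Compound 3 is therefore estimated at 62%, with a range from 35% to 90%.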

Compound 3, a percentage reported as activity, at one dose (the size of the read-out at that dose, not a potency): 100%
Compound 3: middle estimate off by 38 percentage points, on the low side; the whole stated range lies below it.
By their numbers in this assay, from the lowest: compound 1; then compound 2; then compound 3.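

In this assay, within the data shown here, trifluoromethyl in place of hydrogen, ortho to a large group on the six-membered aromatic ring, gives a number 50 percentage points higher from compound 1 to compound 3 (beyond the scatter), a large step, whereas the only earlier change, fluoro in place of hydrogen on an aromatic carbon, gave the modest a number 25 percentage points higher from compound 1 to compound 2 (beyond the scatter). Among these compounds, this shows that the position accepts a group of 4 heavy atoms with a gain in the read-out at the dose given, something the single fluoro compound could not show for either this group or this place. Nothing available here bears on why the trifluoromethyl change gives so large a step.

Compound 2 and compound 3 differ in both the group and its place on the ring, so the compounds shown do not separate what the trifluoromethyl group contributes from what the position contributes. From the compounds shown here alone, it remains open whether a fluoro, a chloro, a methoxy or a nitrile at this same place would match compound 3, and whether trifluoromethyl elsewhere on the ring would do so.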